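The source may report more compounds than this note shows. Statements on the series, on what has been measured and on what is new or still open speak of the compounds shown alone.

Compound 1 `Cc1nc(N)c2c(-c3cccs3)cn([C@@H]3O[C@H](CO)[C@@H](O)[C@H]3O)c2n1`: in a functional assay on HL-60 cells (Homo sapiens) for antiproliferative activity, read by XTT assay, with a stated time of 72 h (a higher number here means a weaker inhibitor, a lower number a stronger inhibitor), compound 1 gives > 20000 nM, a limit of the assay.
Compound 2 `Cc1nc(N)c2c(-c3cc4ccccc4o3)cn([C@@H]3O[C@H](CO)[C@@H](O)[C@H]3O)c2n1`: compound 2 gives > 20000 nM, also a limit.
Compound 3 `CN(C)c1ncnc2c1c(-c1cccs1)cn2[C@@H]1O[C@H](CO)[C@@H](O)[C@H]1O`: compound 3 gives 11800 nM.

The change 1-benzofuran-2-yl in place of thiophen-2-yl on an aromatic carbon yields a step that the two limits leave unreadable from compound 1 to compound 2. Compound 4 `CN(C)c1ncnc2c1c(-c1cc3ccccc3o1)cn2[C@@H]1O[C@H](CO)[C@@H](O)[C@H]1O` carries the same change on the core of compound 3: 1-benzofuran-2-yl in place of thiophen-2-yl on an aromatic carbon. The difference between the core of compound 1 and the core of compound 3 is not broken down here. The measured step gives no guide to its size because of the limit of > 20000 nM in this assay, at which 2 of the 3 values shown sit. The account therefore rests only on the weak value of compound 3 in this assay, 11800 nM, and the estimate for the step from compound 3 to compound 4 is a 1.3-fold higher number from compound 3 to compound 4 (0.10 log units; within the scatter), a change within the usual scatter. Compound 4 is thus expected to reach about 15000 nM, most likely between 5000 nM and 40000 nM, with a fair chance that only a limit is reported.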

Compound 4, half-maximal inhibitory concentration: > 20000 nM
Compound 4 gave a limit, no number; the forecaster's own chance of this, stated with the estimate: 50%; middle value at least 1.3-fold (0.12 log units) away from the limit.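

In this assay the change to 1-benzofuran-2-yl in place of thiophen-2-yl gives an at least 1.6-fold higher number from compound 3 to compound 4 (0.22 log units; that floor lies within the scatter), so on the core of compound 3 it shows no loss beyond the usual scatter, though the true step may be larger. Compound 4 gives > 20000 nM, which is a limit of the assay. The step from compound 1 to compound 2 cannot be read, so the data do not show whether the change has the same size on the two cores: the limit of > 20000 nM in this assay, at which 3 of the 4 values shown sit.

As far as these compounds go, it remains open how an amine, a carboxylic acid or a phenyl group in place of thiophen-2-yl on that aromatic carbon would read in this assay. Also open, from the compounds shown here alone, is whether any such group would give a number clear of the limit on either core.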